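Notes on compound 3 against compounds 1 and 2

The compounds below may be only part of what the source reports. "The series", "measured", "known", "first", "only" and "open" are said of these compounds alone.

Measured:
Compound 1, `COc1cc(-c2nc(C(c3ccc(F)cc3)c3ccc(F)cc3)sc2CC(=O)O)ccn1`: 60%
Compound 2, `O=C(O)Cc1sc(CSc2ccccc2)nc1-c1ccc(Cl)cc1`: 50%

Both numbers come from an in vitro functional assay on HEK285-7 cells for antagonist activity at prostaglandin D2 receptor 2 (Homo sapiens), read by BRET and beta-arrestin recruitment; a lower number here means a smaller maximal response, a higher number a larger maximal response. In this assay compound 1 gives 60%, the higher of the two numbers shown, and compound 2 gives 50%; the gap between the two lies within the usual scatter, so the two maximal responses are read as the same. For the measured compounds named here, no pair of measured compounds differs in only one place, so no measured step is available and no pattern can be drawn from these two compounds alone.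

Compound 3 `Nc1cc(-c2nc(C(c3ccc(F)cc3)c3ccc(F)cc3)sc2CC(=O)O)cc(F)n1` differs from compound 1 in one place: 2-amino-6-fluoropyridin-4-yl in place of 2-methoxypyridin-4-yl on an aromatic carbon. Nothing in the measured data shows what such a swap does to the maximal response. With the two measured compounds sitting at the same level despite quite different groups on the shared core, the expectation is a step no larger than the scatter, in no fixed direction. The change expected, a number 3 percentage points lower from compound 1 to compound 3 (within the scatter), stays within the usual scatter. Compound 3 is therefore expected to give 57% in this assay, with a range from 38% to 76%.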

Compound 3, largest response reached (reported as efficacy), in percent of the reference or control that the assay uses: 30%
Beside the measured number, compound 3's estimate is 27 percentage points above it; measured number below the stated range.
By their numbers in this assay, from the lowest: compound 3; then compounds 2 and 1 (each within the scatter of the next).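

In this assay, for the compounds shown here, 2-amino-6-fluoropyridin-4-yl in place of 2-methoxypyridin-4-yl gives a number 30 percentage points lower from compound 1 to compound 3 (beyond the scatter), the first step that can be read in one place and the first evidence that the maximal response depends on the group on this aromatic carbon, next to the ring nitrogen and next to the ring atom that bears the carboxymethyl group. The change leaves the heavy-atom count and the six-membered aromatic ring with its single hetero atom as they were, so a step beyond the scatter arises here from a swap of the groups on that ring, with a hydrogen-bond donor entering where the leaving group had none. Nothing available bears on why the maximal response falls with this swap.

The swap removes the methoxy group and brings in an amino group and a fluorine together, so the compounds shown do not assign the step to either one; 2-aminopyridin-4-yl and 2-fluoropyridin-4-yl would separate the two. Also open, as far as these compounds go, is whether the step holds when the bis(4-fluorophenyl)methyl group on the shared core is replaced by another group, such as the phenylthiomethyl group of compound 2.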